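The compounds below may be only part of what the source reports. "The series", "measured", "known", "first", "only" and "open" are said of these compounds alone.

Measured compounds, with the value each gives in a functional assay (muscle tissue) with Cavia porcellus as the target; on this read-out higher numbers stand for an effect only at larger amounts of compound and lower numbers for an effect already at smaller amounts:

- compound 1 `COC(=O)C1=C(C)N=C(C)/C(=C(\O)OC)C1c1ccccc1Cl`: 2.19 nM
- compound 2 `COC(=O)C1=C(C)N=C(C)/C(=C(\O)OC)C1c1cccc(N)c1`: 2000 nM
- compound 3 `COC(=O)C1=C(C)N=C(C)/C(=C(\O)OC)C1c1cc(C)ccc1C`: 100 nM

On these numbers compound 3 stands second highest of the three: nearest to it is compound 2, with a 20-fold lower number from compound 2 to compound 3 (1.30 log units; beyond the scatter) separating the two, and furthest from it is compound 1, with a 46-fold higher number from compound 1 to compound 3 (1.66 log units; beyond the scatter) separating them.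

Compound 4 `COC(=O)C1=C(C)N=C(C)/C(=C(\O)OC)C1c1cccc(OC)c1` is not yet measured in this assay. It differs from compound 3 in one place: 3-methoxyphenyl in place of 2,5-dimethylphenyl on a saturated ring carbon.

Among the measured compounds shown here, two measured steps bear on this change. The group that leaves, 2,5-dimethylphenyl, sits in compound 3; the step of a 20-fold lower number from compound 2 to compound 3 (1.30 log units; beyond the scatter) shows that 2,5-dimethylphenyl gave a lower number than 3-aminophenyl. The group that enters, 3-methoxyphenyl, is closest in shape to the 3-aminophenyl of compound 2, and that group gave a 910-fold higher number from compound 1 to compound 2 (2.96 log units; beyond the scatter) against the 2-chlorophenyl of compound 1. Both steps are large. A step of roughly this kind, toward a higher number, is therefore expected for compound 4, though methoxy is not amino and the size carries uncertainty. The expected step is a 5.0-fold higher number from compound 3 to compound 4 (0.70 log units; beyond the scatter). For compound 4 the estimate in this assay is 500 nM, with a range from 100 nM to 3000 nM.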

Compound 4, half-maximal effective concentration: 191 nM
Compound 4: the middle estimate sits 2.6-fold (0.42 log units) above what was measured; the range from low to high includes it.
By their numbers in this assay, from the lowest: compound 1; then compounds 3 and 4 (each within the scatter of the next); then compound 2.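

In this assay, a 1.9-fold higher number from compound 3 to compound 4 (0.28 log units; within the scatter) leaves 3-methoxyphenyl and 2,5-dimethylphenyl on the saturated ring carbon indistinguishable, although the two groups have the same heavy-atom count and only 3-methoxyphenyl has a hydrogen-bond acceptor. The step of a 10-fold lower number from compound 2 to compound 4 (1.02 log units; beyond the scatter) is the only one here confined to a single substituent on an aromatic carbon, and it shows that methoxy and amino are not interchangeable at that carbon. With an 87-fold higher number from compound 1 to compound 4 (1.94 log units; beyond the scatter), 2-chlorophenyl remains clearly apart from the other three aryl groups, and no measurement available here accounts for any of these steps.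

The compounds leave open whether 3-chlorophenyl or 2-methoxyphenyl would give a number close to that of compound 1 or of compound 4, so the substituent and its ring location remain unseparated. Where 3-hydroxyphenyl or 3-nitrophenyl would fall relative to the methoxy and amino groups also remains open.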